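From Compound 1 to Compound 4 in Paw Edema

The source may hold more compounds than are shown below. What is called first, only, known or untested is meant among the compounds shown, and "the series" means these compounds.

Compound 1 `O=C(N/N=C/c1ccc(F)cc1)c1cccnc1Nc1cccc(C(F)(F)F)c1`: 41.3%
Compound 2 `O=C(N/N=C/c1cccc(Cl)c1)c1cccnc1Nc1cccc(C(F)(F)F)c1`: 55.2%
Compound 3 `COc1ccc(/C=N/NC(=O)c2cccnc2Nc2cccc(C(F)(F)F)c2)c(OC)c1`: 24.1%

All three values come from a functional assay on the whole organism (strain Wistar) for inhibition, with Rattus norvegicus as the target, read by paw edema, with a stated time of 3 h, at a dose of 10 mg/kg by the intraperitoneal route; on this read-out lower numbers stand for less inhibition and higher numbers for more inhibition at the one dose given (going by the name of the read-out). Compound 1 stands second highest of the three numbers; its nearest neighbour is a number 13.9 percentage points higher from compound 1 to compound 2 (beyond the scatter), and its furthest is a number 17.2 percentage points lower from compound 1 to compound 3 (beyond the scatter), both beyond the scatter. Compound 4 `O=C(N/N=C/c1ccncc1)c1cccnc1Nc1cccc(C(F)(F)F)c1` has not yet been measured in this assay and differs from compound 1 in one place: pyridin-4-yl in place of 4-fluorophenyl on a carbon with a double bond to nitrogen. The two measured steps that bear on it change the same group on the same carbon; both were modest, one upward and one downward, and neither brings in pyridin-4-yl, so the direction for compound 4 is open. Compound 4 is therefore expected to stay near compound 1, with an estimated step of a number 3.3 percentage points lower from compound 1 to compound 4 (within the scatter). The estimated value for compound 4 is 38%, in a range from 22% to 55%.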

Compound 4, a percentage reported as inhibition, in the whole organism at one dose (the size of the read-out at that dose, not a potency): 54.9%
For compound 4 the middle estimate is 16.9 percentage points below the measured one; low and high end bracket the measured number.
By their numbers in this assay, from the lowest: compound 3; then compound 1; then compounds 4 and 2 (each within the scatter of the next).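

With pyridin-4-yl, compound 4 alone among these compounds carries a ring with a hetero atom at this place, and this assay shows a number 13.6 percentage points higher from compound 1 to compound 4 (beyond the scatter) and a number 30.8 percentage points higher from compound 3 to compound 4 (beyond the scatter) on this carbon. The same read-out gives a number 0.3 percentage points lower from compound 2 to compound 4 (within the scatter), so pyridin-4-yl and 3-chlorophenyl cannot be told apart here. Nothing available explains the rise over 4-fluorophenyl. Open remains how a pyridin-3-yl ring, or a phenyl ring carrying an amine or a carboxylic acid, would read on this carbon.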